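Aryl exchange on the shared core

The source may hold more compounds than are shown below. What is called first, only, known or untested is meant among the compounds shown, and "the series" means these compounds.

Compound 1 `CCCS(=O)(=O)Nc1ccc(F)c(C(=O)c2n[nH]c3ncc(-c4ccccc4F)cc23)c1F` and compound 2 `CCCS(=O)(=O)Nc1ccc(F)c(C(=O)c2n[nH]c3ncc(-c4cccc(OC)c4)cc23)c1F` share one core. In an assay for binding affinity to dual specificity mitogen-activated protein kinase kinase 4 (Homo sapiens), read by KINOMEscan, tested at 100 nM (a lower number here means a stronger effect, a higher number a weaker effect of the compound at the concentration tested), compound 1 gives 2%. In this assay compound 2 gives 6.3%, the upper of the two numbers, with compound 1 nearest and within the scatter. For the measured compounds named here, the single measured step, a number 4.3 percentage points higher from compound 1 to compound 2 (within the scatter), leaves the read-out flat. Compound 3 `CCCS(=O)(=O)Nc1ccc(F)c(C(=O)c2n[nH]c3ncc(-c4ccccc4N)cc23)c1F` carries 2-aminophenyl in place of 3-methoxyphenyl on an aromatic carbon. Going by the values given here, only that step bears on the change, so no shift beyond the scatter is expected in this assay. The expected step is a number 1.3 percentage points lower from compound 2 to compound 3 (within the scatter). Compound 3 is estimated at 5%, range 1% to 20%.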

Compound 3, a percentage reported as activity, at one concentration (the size of the read-out at that concentration, not a potency): 23%
Estimate against measurement, compound 3: 18 percentage points below, and the stated range ends below it.
By their numbers in this assay, from the lowest: compounds 1 and 2 (each within the scatter of the next); then compound 3.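

Unlike the earlier aryl exchange, this change moves the read-out in this assay. The 2-aminophenyl group in place of 3-methoxyphenyl gives a number 16.7 percentage points higher from compound 2 to compound 3 (beyond the scatter), and amino in place of fluoro on the aryl ring gives a number 21 percentage points higher from compound 1 to compound 3 (beyond the scatter), so this position does not tolerate every aryl group equally. No available evidence accounts for the shift.

As far as these compounds go, whether it follows the amino group itself or its place on the ring remains open. A 3-aminophenyl, a 2-hydroxyphenyl or a 2-methoxyphenyl group would help to separate these.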